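The source may report more compounds than this note shows. Statements on the series, on what has been measured and on what is new or still open speak of the compounds shown alone.

Compound 1 `CCCCS(=O)(=O)N1CCC2(CC1)OOC1(CCCCC1)OO2` and compound 3 `O=S(=O)(CCCCl)N1CCC2(CC1)OOC1(CCCCC1)OO2` share one core; compound 2 `CCCCS(=O)(=O)N1CCC2(CC1)OOC1(CCCCCC1)OO2` and compound 4 `O=S(=O)(CCCCl)N1CCC2(CC1)OOC1(CCCCCC1)OO2` share another, and the difference between the two cores is not broken down here. In a functional assay on Huh-7 cells (Homo sapiens) for cytotoxicity, read by MTT assay, with a stated time of 72 h (on this read-out higher numbers stand for lower toxicity in this test and lower numbers for higher toxicity in this test), compound 1 reaches only the limit of the test, > 100 ug/mL. In this assay compound 3 likewise gives only a limit, > 100 ug/mL. In this assay compound 2 also stops at a limit, > 100 ug/mL. The change from compound 1 to compound 3 is chloro in place of methyl on a saturated chain carbon, three bonds along the chain from a sulfonyl sulfur; its step, a step that the two limits leave unreadable from compound 1 to compound 3, cannot be sized because of the limit of > 100 ug/mL in this assay, at which 3 of the 3 values shown sit. The same change, (chloro in place of methyl on a saturated chain carbon, three bonds along the chain from a sulfonyl sulfur), takes compound 2 to compound 4. For compound 4 the expected step in this assay is a number no higher from compound 2 to compound 4 (the limit leaves the size open). That expectation rests on compound 3, which after the same change holds only the limit > 100 ug/mL. Compound 4 is estimated at 100 ug/mL, most likely again reported as a limit.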

Compound 4, half-maximal cytotoxic concentration: > 100 ug/mL
Compound 4: only a limit was reported (the forecaster's own chance of this, stated with the estimate: 85%); the middle value lies on the limit itself.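

No step can be read between compound 2 and compound 4 in this assay, because both stop at a limit: the limit of > 100 ug/mL in this assay, at which 4 of the 4 values shown sit.

Going by these compounds, whether chloro in place of methyl, or the difference between the two cores, alters cytotoxicity at all remains open.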